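A few compounds are considered here, and "the series" means these few. Any claim that something is new, unique, unknown or untested is made for them only; others in the source may bear on it.

Measured in an ADME assay on L6 cells (Rattus norvegicus) for cytotoxicity, read by resazurin assay; on this read-out higher numbers stand for weaker inhibition and lower numbers for stronger inhibition:
- Compound 1 `N=C(N)c1ccc2[nH]c(-c3ccc4nc(-c5ccc(F)c(F)c5)[nH]c4c3)nc2c1`: 29.8 ug/mL
- Compound 2 `COc1ccc(-c2nc3ccc(-c4nc5cc(C(=N)N)ccc5[nH]4)cc3[nH]2)cc1OC`: > 90 ug/mL

The value for compound 2 is a limit of the assay and not a number. Compound 2 thus stands at the limit of > 90 ug/mL in this assay, at which 1 of the 2 values shown sits.

Compound 3 `N=C(N)c1ccc2[nH]c(-c3ccc4nc(-c5cccc6ccccc56)[nH]c4c3)nc2c1` differs from compound 2 at one place, on an aromatic carbon of a five-membered aromatic ring with 2 nitrogen, where naphthalen-1-yl takes the place of 3,4-dimethoxyphenyl (naphthalen-1-yl in place of 3,4-dimethoxyphenyl on an aromatic carbon).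

Among the compounds with values here, only one measured step bears on this change, and it concerns the same place: an at least 3.0-fold higher number from compound 1 to compound 2 (0.48 log units; beyond the scatter). There, the 3,4-dimethoxyphenyl compound has the higher number, meaning weaker inhibition. Compound 3 lacks that group, as compound 1 does, so a return towards the level of compound 1 is expected, though naphthalen-1-yl itself has not been measured in this series. A step to a lower number in this assay is therefore expected, of modest size, and its exact size remains uncertain while the starting point is only a limit.

The expected change is an at least 3.0-fold lower number from compound 2 to compound 3 (0.47 log units; beyond the scatter).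

For compound 3 the estimated value is 30 ug/mL, with an expected range from 9 ug/mL to 90 ug/mL.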

Compound 3, half-maximal inhibitory concentration: 8.72 ug/mL
Estimate against measurement, compound 3: 3.4-fold (0.54 log units) above; the whole stated range lies above it.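

In this assay, the aromatic carbon between two ring nitrogen atoms can carry a group that takes the number below the level of the 3,4-difluorophenyl compound as well as above it, with naphthalen-1-yl giving a 3.4-fold lower number from compound 1 to compound 3 (0.53 log units; beyond the scatter). Exchanging 3,4-dimethoxyphenyl for naphthalen-1-yl, two groups of equal heavy-atom count, gives an at least 10-fold lower number from compound 2 to compound 3 (1.01 log units; beyond the scatter), so this place responds strongly to the identity of the aromatic group and not merely to its size in heavy atoms. The value of compound 2 is a limit of the assay, so the full size of that step stays unknown: the limit of > 90 ug/mL in this assay, at which 1 of the 3 values shown sits.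

The compounds shown do not separate the second aromatic ring of naphthalen-1-yl from the loss of the two methoxy oxygens, nor do they tell how naphthalen-2-yl or an unsubstituted phenyl would read at this place. Every group shown here is aromatic, so a cyclohexyl ring or a short chain ending in an amine remains an open case for this position.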